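Methyl in place of tert-butyl: working notes

The source may report more compounds than this note shows. Statements on the series, on what has been measured and on what is new or still open speak of the compounds shown alone.

Values in a functional assay on MDA-MB-231 cells (Homo sapiens) for cytotoxicity, read by MTT assay, with a stated time of 72 h; a higher number here means a weaker inhibitor, a lower number a stronger inhibitor:
- compound 1 `CCN(CC)Cc1ccc2nc(NC(=O)N/N=C/c3cn(Cc4ccc(C(C)(C)C)cc4)c4ccccc34)sc2c1`: 2120 nM
- compound 2 `CN(C)Cc1ccc2nc(NC(=O)N/N=C/c3cn(Cc4ccc(C(C)(C)C)cc4)c4ccccc34)sc2c1`: 2230 nM
- compound 3 `CC1CCN(Cc2ccc3nc(NC(=O)N/N=C/c4c[nH]c5ccccc45)sc3c2)CC1`: 2460 nM

Compound 1 lies within the scatter of both compound 2 and compound 3, so the three values give no order. Compound 4 `CCN(CC)Cc1ccc2nc(NC(=O)N/N=C/c3cn(Cc4ccc(C)cc4)c4ccccc34)sc2c1` differs from compound 1 in one place, with methyl in place of tert-butyl on an aromatic carbon. Within the data shown here, the only measured step, a 1.1-fold higher number from compound 1 to compound 2 (0.02 log units; within the scatter), swaps diethylamino for dimethylamino, stays within the scatter and does not touch this group. Among the measured compounds shown here, no measured step isolates the present change, so the evidence is indirect. Compound 3 carries no 4-(tert-butyl)benzyl group and also differs in its amine, yet it gives 2460 nM, a value within the scatter of compound 1. No shift beyond the scatter is therefore expected in this assay, and the direction is left open. The estimated step is a 1.1-fold higher number from compound 1 to compound 4 (0.04 log units; within the scatter). Compound 4 is expected at 2300 nM, with an estimated range of 1200 nM to 4500 nM.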

Compound 4, half-maximal inhibitory concentration: 2010 nM
Compound 4: middle estimate off by 1.1-fold (0.06 log units), on the high side; measured number inside the range.
By their numbers in this assay, from the lowest: compounds 4, 1, 2 and 3 (each within the scatter of the next).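

In this assay, among these compounds, the step of a 1.1-fold lower number from compound 1 to compound 4 (0.02 log units; within the scatter) is the first to isolate this position, with the diethylamino side chain and the shared core held constant. Going from tert-butyl, with 4 heavy atoms, to methyl, with 1 heavy atom, on this aromatic carbon therefore produces no shift beyond the scatter. Among the compounds shown here, the indirect reading from the earlier compounds now has a direct matched pair behind it, although this single pair says nothing about other substituents at this position or about other amines.

The compounds shown leave open whether a carboxylic acid, a primary amine or a longer alkyl chain on this aromatic carbon would keep the number within the scatter of compound 1. No measurement on hand explains why this change leaves the number within the scatter.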